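The source may hold more compounds than are shown below. What is called first, only, known or untested is meant among the compounds shown, and "the series" means these compounds.

Compound 3 `CN(Cc1ccccc1F)C(=O)CNC(=O)c1ccc(S(C)(=O)=O)c([N+](=O)[O-])c1` is tested in an assay on isolated protein for inhibition of thyroid hormone receptor alpha (Homo sapiens), read by fluorescence polarization (a lower number here means a stronger inhibitor, a higher number a weaker inhibitor), and returns only a limit, > 60000 nM, not a number. Compound 1 `Cc1ccc(N2CCN(C(=O)C3CCN(C(=O)c4ccc(S(C)(=O)=O)c([N+](=O)[O-])c4)CC3)CC2)cc1` returns the same kind of limit in this assay, > 60000 nM. Compound 2 `CN(Cc1ccccc1F)C(=O)C1CCN(C(=O)c2ccc(S(C)(=O)=O)c([N+](=O)[O-])c2)CC1` likewise gives a limit in this assay, > 60000 nM. Among the compounds with values here, compound 3 therefore stands together with both of them at the limit of > 60000 nM in this assay, at which 3 of the 3 values shown sit, and nothing among the measured values separates any of the three from the others.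

Compound 4 `CN(Cc1cccc(F)c1)C(=O)CNC(=O)c1ccc(S(C)(=O)=O)c([N+](=O)[O-])c1` has not been measured. It differs from compound 3 by 3-fluorophenyl in place of 2-fluorophenyl on a saturated chain carbon bound to an amide-type nitrogen, the two compounds having the same atoms joined differently. Within the data shown here, no pair of measured compounds isolates this change, so no size for it can be read from the data.

Compound 3 sits at the limit of this assay, and compound 4 is expected to do the same. The step of a number no higher from compound 3 to compound 4 (the limit leaves the size open) is estimated as none beyond the scatter. Compound 4 is estimated at 60000 nM in this assay, with a range from 20000 nM to 200000 nM, and most likely again reported only as a limit.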

Compound 4, half-maximal inhibitory concentration: > 60000 nM
Compound 4 was reported as a limit; the forecaster's own chance of this, stated with the estimate: 85%; the middle value lies on the limit itself.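

Within the data shown here, compound 3 and compound 4 both return only a limit in this assay, and no step between the 2-fluorophenyl and the 3-fluorophenyl can be read from them. The compounds shown leave open how strongly, if at all, any of them inhibits, as all stand together: the limit of > 60000 nM in this assay, at which 4 of the 4 values shown sit.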